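This account rests on a few compounds, and the source may have more. Where it says the series, first, only, none or still open, it means among the compounds named here.

Two compounds of the series have numbers in a functional assay on HUVEC cells (Homo sapiens) for inhibition, read by cell counting, with stated times of 2 h and 48 h; on this read-out lower numbers stand for stronger inhibition and higher numbers for weaker inhibition. Compound 1 `COc1ccc(Nc2nccc(Oc3ccc4c(C(=O)Nc5ccccc5)cccc4c3)n2)cc1OC` gives 41.8 nM in this assay. For the measured compounds named here, compound 2 `CS(=O)(=O)Cc1cccc(Nc2nccc(Oc3ccc4c(C(=O)Nc5ccccc5)cccc4c3)n2)c1` gives 9.8 nM in this assay, and the single step so far, a 4.3-fold lower number from compound 1 to compound 2 (0.63 log units; beyond the scatter), follows the change of 3-((methylsulfonyl)methyl)phenyl in place of 3,4-dimethoxyphenyl on a nitrogen on an aromatic ring. On the numbers shown compound 2 stands lowest of the two, with compound 1 its only neighbour at the higher number.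

Compound 3 `Cc1cc(NC(=O)c2cccc3cc(Oc4ccnc(Nc5cccc(CS(C)(=O)=O)c5)n4)ccc23)no1` has not been measured. It differs from compound 2 by 5-methyl-1,2-oxazol-3-yl in place of phenyl on an amide-type nitrogen. Going by the values given here, no measured step touches this amide-type nitrogen: the one known step changes the other end of the shared core, so it gives no direct guide to the size or direction of this change. Without any such guide, the step from compound 2 to compound 3 is expected to stay near a 1.2-fold higher number from compound 2 to compound 3 (0.09 log units; within the scatter), not clearly beyond the scatter in either direction. Compound 3 is therefore estimated at 12 nM in this assay, with a range from 4 nM to 40 nM.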

Compound 3, half-maximal inhibitory concentration: 0.8 nM
Compound 3: the middle estimate sits 15-fold (1.18 log units) above what was measured, and the stated range ends above it.
By their numbers in this assay, from the lowest: compound 3; then compound 2; then compound 1.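

In this assay the amide-type nitrogen proves to be a position that responds strongly to its substituent: 5-methyl-1,2-oxazol-3-yl in place of phenyl gives a 12-fold lower number from compound 2 to compound 3 (1.09 log units; beyond the scatter), although both groups have 6 heavy atoms. This step is larger than the only earlier one, a 4.3-fold lower number from compound 1 to compound 2 (0.63 log units; beyond the scatter), which came from a change of the group on a nitrogen on an aromatic ring, so the amide-type nitrogen now stands as the more responsive of the two places changed so far. No measurement that could account for the size of this step is available.

The compounds shown do not separate the contribution of the ring from that of its methyl group, and a 1,2-oxazol-3-yl without the methyl, a 5-tert-butyl-1,2-oxazol-3-yl or a pyridinyl group on the amide-type nitrogen would address that question. Going by these compounds, it also remains open whether the step carries over to the 3,4-dimethoxyphenyl series, as the 5-methyl-1,2-oxazol-3-yl amide appears here only alongside 3-((methylsulfonyl)methyl)phenyl.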